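This account rests on a few compounds, and the source may have more. Where it says the series, first, only, none or still open, it means among the compounds named here.

So far, two compounds have numbers: compound 1 (`O=C(O)CCCCC(CCSC(=O)c1ccccc1)SC(=O)c1ccccc1`) and compound 2 (`O=C(CCCCC(S)CCS)NO`). In a functional assay on NCI-H460 cells (Homo sapiens) for inhibition, read by MTT assay, with a stated time of 24 h, tested at 1 ug/mL (a higher number here means more inhibition of growth at the concentration tested, a lower number less inhibition of growth), compound 1 gives 0.77% and compound 2 gives 1.17%. These two values lie within the usual scatter of each other, so compound 2 stands level with compound 1, and neither shows more than slight inhibition of growth at the concentration tested. Compound 3 (`O=C(CCCCC(S)CCS)Nc1ccccc1`) keeps the chain of compound 2 and alters only its end: phenyl in place of hydroxy on an amide-type nitrogen, with phenyl in place of hydroxy on an amide-type nitrogen. Among the measured compounds shown here, no measured pair shows what such a swap does, so the expectation rests on the low starting value of compound 2, 1.17%, and no change beyond the scatter is foreseen. The expected change is small, a number 0.8 percentage points higher from compound 2 to compound 3 (within the scatter). In this assay, compound 3 is estimated at 2%, with an expected range from 0% to 12%.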

Compound 3, percent growth inhibition at one concentration: 4.3%
Compound 3: the middle estimate sits 2.3 percentage points below what was measured; the range from low to high includes it.
By their numbers in this assay, from the lowest: compounds 1, 2 and 3 (each within the scatter of the next).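

In this assay, phenyl in place of hydroxy on an amide-type nitrogen gives a number 3.1 percentage points higher from compound 2 to compound 3 (within the scatter), so this one swap does not separate the two compounds. The swap is a large one in plain atom count: 6 heavy atoms and a six-membered aromatic ring of carbon only enter where 1 oxygen leaves, and the hydrogen-bond donor and acceptor counted for hydroxy go with it, yet the reading stays within the scatter. Nothing available explains this result.

The compounds shown leave open whether a different group on this nitrogen, such as a benzyl group, a pyridine ring or a longer carbon chain, would move the number beyond the scatter. They also leave open whether a phenyl ring carrying a methoxy group or a chlorine would read any differently from plain phenyl.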